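The source may report more compounds than this note shows. Statements on the series, on what has been measured and on what is new or still open speak of the compounds shown alone.

Compound 1 `O=C1Nc2ccccc2/C1=N/NC(=S)N1CCN(c2ccccc2)CC1` was tested in a functional assay on A549 cells (Homo sapiens) for inhibition, read by MTT assay, with a stated time of 72 h (on this read-out lower numbers stand for stronger inhibition and higher numbers for weaker inhibition), where compound 1 gave 18600 nM. Compound 2 `Cc1ccc2c(c1)/C(=N/NC(=S)N1CCN(c3ccccc3)CC1)C(=O)N2` differs from it in one place: methyl in place of hydrogen on an aromatic carbon The step measured as a 1.9-fold lower number from compound 1 to compound 2 (0.27 log units; within the scatter). Compound 3 `Cc1ccccc1N1CCN(C(=S)N/N=C2\C(=O)Nc3ccc(Cl)cc32)CC1` carries a different core; how the core of compound 1 and the core of compound 3 differ is not broken down here. In this assay compound 3 gave 6520 nM, whereas compound 2 gave 9880 nM; these two numbers lie within the scatter of each other. Compound 4 `Cc1ccc(N2CCN(C(=S)N/N=C3\C(=O)Nc4ccc(Cl)cc43)CC2)c(C)c1` has not yet been measured. For the measured compounds named here, its difference from compound 3 is methyl in place of hydrogen on an aromatic carbon This is the same kind of change as the one between compound 1 and compound 2, though not the same: there the place was part of a fused or bridged system of two rings, meta to a fused ring and para to a fused ring, whereas here it is meta to a methyl group and para to a large group. The expectation rests on the earlier step, a 1.9-fold lower number from compound 1 to compound 2 (0.27 log units; within the scatter), which fell within the scatter. A similarly small step is therefore expected: a 1.4-fold lower number from compound 3 to compound 4 (0.16 log units; within the scatter). Compound 4 is accordingly estimated to give 4500 nM, between 2000 nM and 12000 nM.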

Compound 4, half-maximal inhibitory concentration: 3590 nM
Estimate against measurement, compound 4: 1.3-fold (0.10 log units) above; measured number inside the range.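

In this assay, turning the 2-methylphenyl group into the 2,4-dimethylphenyl group came with a 1.8-fold lower number from compound 3 to compound 4 (0.26 log units; within the scatter). Set beside the earlier methyl step, this gives two steps that do not differ from one another: the same change on two cores in this assay, a 1.9-fold lower number (0.27 log units; within the scatter) from compound 1 to compound 2 and a 1.8-fold lower number (0.26 log units; within the scatter) from compound 3 to compound 4, 1.0-fold (0.02 log units) apart, within the scatter of two such steps. The change therefore carried over between these two cores with no detectable difference in the size of the step, but each step on its own lies within the scatter, so neither pair establishes a real effect of the methyl group, and the methyl sits in a different place in each pair, so two pairs cannot show how the change would behave on other cores in this series.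

The compounds shown leave open whether another group at the same place, such as a methoxy group, an amine or a carboxylic acid, would give a step beyond the scatter. They also leave open whether a longer chain there, such as ethyl, would behave as methyl does.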